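Replacing one group on an amine nitrogen of compound 2

This account rests on a few compounds, and the source may have more. Where it says the series, first, only, none or still open, it means among the compounds named here.

Compound 1 `COc1ccc(Oc2ccc(C(C)C)cc2-c2ccsc2S(=O)(=O)NCCNC(=S)Nc2ccc([N+](=O)[O-])cc2)cc1OC` gives 11900 nM
Compound 2 `COc1ccc(NC(=S)NCCNS(=O)(=O)c2sccc2-c2ccc(C)cc2Oc2ccc(O)c(O)c2)cc1` gives > 20000 nM (a limit)

Both compounds were tested in a functional assay on HeLa cells (Homo sapiens) for inhibition, read by CCK-8 assay, with a stated time of 48 h; a lower number here means a stronger inhibitor, a higher number a weaker inhibitor. Compound 2 has no number, only a limit: the limit of > 20000 nM in this assay, at which 1 of the 2 values shown sits. Among the measured compounds shown here, compound 1 gives 11900 nM, the only true number in the set.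

Compound 3 `Cc1ccc(-c2ccsc2S(=O)(=O)NCCNC(=O)Nc2cc(Cl)cc(Cl)c2)c(Oc2ccc(O)c(O)c2)c1` departs from compound 2 in a single place: a group of 11 heavy atoms (7 carbon, 1 nitrogen, 1 oxygen, 2 chlorine; one six-membered aromatic ring of carbon only) in place of a group of 11 heavy atoms (8 carbon, 1 nitrogen, 1 oxygen, 1 sulfur; one six-membered aromatic ring of carbon only), on an amine nitrogen. The (3,5-dichlorophenyl)carbamoyl group enters on an amine nitrogen, and the core stays the same.

For the measured compounds named here, no measured step between compounds differing in one place is available as a guide, so only a modest gain in this assay is expected. The expected change, toward stronger inhibition, is an at least 1.6-fold lower number from compound 2 to compound 3 (0.22 log units; that floor lies within the scatter). For compound 3 the estimated value is 12000 nM, with an expected range from 5000 nM to 30000 nM.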

Compound 3, half-maximal inhibitory concentration: 6500 nM
Beside the measured number, compound 3's estimate is 1.8-fold (0.27 log units) above it; measured number inside the range.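

On the amine nitrogen of the shared core, this assay responds to a change of group: entry of the (3,5-dichlorophenyl)carbamoyl group gives an at least 3.0-fold lower number from compound 2 to compound 3 (0.48 log units; beyond the scatter). Among the compounds shown here, this is the first step at this position, and it lies beyond the usual scatter, with compound 3 reading as a true number inside the assay's range. The step is only a lower bound on the change, because compound 2 has a limit and no number: the limit of > 20000 nM in this assay, at which 1 of the 3 values shown sits.

The exchange alters sulfur to oxygen and the ring substituents together, so the compounds shown do not separate the contribution of each. As far as these compounds go, it also remains open how this position would respond to a plain phenylcarbamoyl group or a (3,5-difluorophenyl)carbamoyl group in this assay.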